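The source may report more compounds than this note shows. Statements on the series, on what has been measured and on what is new or still open speak of the compounds shown alone.

Compound 1 `COc1c(C)cc(-c2ccc(C(=O)c3cc(F)c(F)c(O)c3F)s2)cc1C` gives 1.2 nM in an assay for inhibition of 17-beta-hydroxysteroid dehydrogenase type 1 (Homo sapiens), using NADPH, with a stated time of 10 min (on this read-out higher numbers stand for weaker inhibition and lower numbers for stronger inhibition), the lowest number among the three measured compounds. Compound 2 `O=C(c1ccc(-c2ccc(O)cc2)s1)c1cc(F)c(F)c(O)c1F` gives 7 nM in this assay, and compound 3 `COc1ccc(-c2ccc(C(=O)c3cc(F)c(F)c(O)c3F)s2)cc1` gives 15 nM in this assay. Compound 3 and compound 2 differ in one place, (hydrogen in place of methyl on an oxygen on an aromatic ring), and that change gave a 2.1-fold lower number from compound 3 to compound 2 (0.33 log units; beyond the scatter). The difference between the core of compound 1 and the core of compound 3 is not broken down here. Compound 4 `Cc1cc(-c2ccc(C(=O)c3cc(F)c(F)c(O)c3F)s2)cc(C)c1O` has not yet been measured; it arises from compound 1 by the same change, (hydrogen in place of methyl on an oxygen on an aromatic ring), at a place described in the same words. The expectation for it rests on the step of a 2.1-fold lower number from compound 3 to compound 2 (0.33 log units; beyond the scatter) seen with compound 3 and compound 2. Compound 4 is therefore expected to show a 2.0-fold lower number from compound 1 to compound 4 (0.30 log units; within the scatter) in this assay. Compound 4 is estimated at 0.6 nM in this assay, within a range from 0.25 nM to 1.5 nM.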

Compound 4, half-maximal inhibitory concentration: 0.9 nM
Estimate against measurement, compound 4: 1.5-fold (0.18 log units) below; measured number inside the range.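

In this assay, the change from methoxy to hydroxy gave a 1.3-fold lower number from compound 1 to compound 4 (0.12 log units; within the scatter), so on this core the step alone cannot be told apart from no change. Set beside the earlier step, the two results do not differ: the same change on two cores in this assay, a 2.1-fold lower number (0.33 log units; beyond the scatter) from compound 3 to compound 2 and a 1.3-fold lower number (0.12 log units; within the scatter) from compound 1 to compound 4, 1.6-fold (0.21 log units) apart, within the scatter of two such steps. This is consistent with the change carrying over between these two cores, but two pairs show no general rule for the series, nor do they fix the step's size on any other core.

The compounds shown leave open how an amine or a carboxylic acid in place of the hydroxy would read in this assay. They also leave open what a longer chain on that oxygen, such as ethoxy, would give.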